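Swapping Methoxy for Fluoro on the Aniline Ring

A few compounds are considered here, and "the series" means these few. Any claim that something is new, unique, unknown or untested is made for them only; others in the source may bear on it.

Of the compounds shown here, three sharing one core have been tested in a functional assay on B16-F10 cells (Mus musculus) for cytotoxicity, read by MTT assay, with a stated time of 48 h; on this read-out lower numbers stand for stronger inhibition and higher numbers for weaker inhibition. Compound 1 `COc1ccc(-c2nc(C(=O)/C=C\Nc3ccc4[nH]ccc4c3)c3ccccn23)cc1` gives 5120 nM, compound 2 `COc1ccc(N/C=C\C(=O)c2nc(-c3ccc(F)cc3)n3ccccc23)cc1` gives 2560 nM, and compound 3 `COc1ccc(N/C=C\C(=O)c2nc(-c3ccc(OC)cc3)n3ccccc23)cc1` gives 2120 nM. Compound 3 therefore shows the lowest number of the three: against compound 1 the step is clear, a 2.4-fold lower number from compound 1 to compound 3 (0.38 log units; beyond the scatter), while against compound 2 it is not, a 1.2-fold lower number from compound 2 to compound 3 (0.08 log units; within the scatter).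

Compound 4 `COc1ccc(-c2nc(C(=O)/C=C\Nc3ccc(F)cc3)c3ccccn23)cc1` is not yet measured. Going by the values given here, its difference from compound 3 lies on the other aromatic ring from the one changed between compound 2 and compound 3: fluoro in place of methoxy on an aromatic carbon. Among the compounds with values here, the only comparable step available is the reverse exchange on the ring attached to the core, a 1.2-fold lower number from compound 2 to compound 3 (0.08 log units; within the scatter), which stayed within the scatter. Within the data shown here, no step on the aniline ring itself has been measured, so that single example is the whole basis.

From it, compound 4 is expected to sit close to compound 3, a 1.2-fold higher number from compound 3 to compound 4 (0.09 log units; within the scatter), with perhaps a slightly higher number. The estimate for compound 4 in this assay is 2600 nM, within a range from 1300 nM to 5200 nM.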

Compound 4, half-maximal inhibitory concentration: > 30000 nM
Compound 4: only a limit was reported; the forecaster's own chance of this, stated with the estimate: 5%; middle value at least 11-fold (1.06 log units) away from the limit.
By their numbers in this assay, from the lowest: compounds 3, 2 and 1 (each within the scatter of the next, the first and the last beyond it). At a limit, above all of these: compound 4.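

In this assay, the aniline ring proves far more sensitive than the ring on the core: fluoro in place of methoxy here gives an at least 14-fold higher number from compound 3 to compound 4 (1.15 log units; beyond the scatter), whereas the matching exchange on the other ring stayed within the scatter, a 1.2-fold lower number from compound 2 to compound 3 (0.08 log units; within the scatter). On the same amine nitrogen, 4-fluorophenyl in place of 1H-indol-5-yl gives an at least 5.8-fold higher number from compound 1 to compound 4 (0.76 log units; beyond the scatter), so 4-methoxyphenyl and 1H-indol-5-yl both give numbers here, while 4-fluorophenyl reaches a limit. Compound 4 is recorded only as a limit, so both steps are minimum sizes: the limit of > 30000 nM in this assay, at which 1 of the 4 values shown sits.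

Still open, on these data alone, is whether the large step comes from losing methoxy or from gaining fluoro; a plain hydrogen, a chloro group or a hydroxyl group at this position would help separate the two. Also open, as far as these compounds go, is how 4-fluorophenyl on the aniline nitrogen behaves when the ring on the core carries fluoro as well.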